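Chromone dithiocarbamates: amine swap on the thiocarbonyl

This account rests on a few compounds, and the source may have more. Where it says the series, first, only, none or still open, it means among the compounds named here.

Measured so far in a functional assay on LM7 cells (Homo sapiens) for antiproliferative activity, read by MTT assay, with a stated time of 72 h; on this read-out lower numbers stand for stronger inhibition and higher numbers for weaker inhibition:
- compound 1, `Cc1ccc2c(=O)c(CSC(=S)N(C(C)C)C(C)C)coc2c1`, 6300 nM
- compound 2, `CC(C)N(C(=S)SCc1coc2cc(Cl)ccc2c1=O)C(C)C`, a limit of this assay, > 25000 nM
- compound 3, `O=c1cc(CSC(=S)N2CCCC2)oc2ccccc12`, 40000 nM

Compound 1 gives the lowest number of the two that are numbers; compound 3 sits far higher, and compound 2 returns only a limit, see (the limit of > 25000 nM in this assay, at which 1 of the 3 values shown sits). Among the compounds with values here, the single one-place step in the set, an at least 3.9-fold higher number from compound 1 to compound 2 (0.59 log units; beyond the scatter), concerns the aromatic ring and not the amine, so it gives no direct guidance for the change considered here.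

Compound 4, `Cc1ccc2c(=O)c(CSC(=S)N3CCCC3)coc2c1`, differs from compound 1 by pyrrolidin-1-yl in place of diisopropylamino on a thiocarbonyl carbon. Within the data shown here, no measured pair isolates this exchange. Compound 3 does carry pyrrolidin-1-yl and shows a much higher number than compound 1, but it differs from compound 1 in more than one place, so only the two values can be noted. With that as the only hint, a move toward weaker inhibition is expected for compound 4, of the size a 2.4-fold higher number from compound 1 to compound 4 (0.38 log units; beyond the scatter). The expected value for compound 4 in this assay is 15000 nM, with a range of 5000 nM to 45000 nM.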

Compound 4, half-maximal inhibitory concentration: 3400 nM
For compound 4 the middle estimate is 4.4-fold (0.64 log units) above the measured one; measured number below the stated range.
By their numbers in this assay, from the lowest: compounds 4 and 1 (each within the scatter of the next); then compound 3.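

On the core of compound 1, the thiocarbonyl carbon takes pyrrolidin-1-yl in place of diisopropylamino with a 1.9-fold lower number from compound 1 to compound 4 (0.27 log units; within the scatter), so this assay does not tell the two amines apart. Within the data shown here, this is the first pair that isolates the exchange, and it shows that the open-chain diisopropylamino group is not required at this position: a five-membered ring serves equally well on this read-out. Nothing measured here speaks to the reason for this outcome.

Compound 2 gives only a limit of this assay, > 25000 nM, which leaves open whether the exchange would read the same way on the chloro core. Also open, as far as these compounds go, is how piperidin-1-yl, morpholin-4-yl or dimethylamino on the thiocarbonyl carbon would fare in this assay on the core of compound 1.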